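Chloro added to the phenyl of compound 3

The compounds below may be only part of what the source reports. "The series", "measured", "known", "first", "only" and "open" are said of these compounds alone.

Compound 3 `NC(N)=NC(=O)c1nc(Cl)c(Nc2ccccc2)nc1N` gives 44% in an assay for inhibition of acid-sensing ion channel 3 (Homo sapiens), read by patch clamp, tested at 1 uM (a higher number here means more inhibition at the concentration tested (going by the name of the read-out), a lower number less inhibition), the highest of the three measured numbers; compound 2 `NC(N)=NC(=O)c1nc(Cl)c(NCC2CCCCC2)nc1N` gives 28% and compound 1 `NC(N)=NC(=O)c1nc(Cl)c(NC2CCCCC2)nc1N` gives 21%. The steps of a number 23 percentage points higher from compound 1 to compound 3 (beyond the scatter) and a number 16 percentage points higher from compound 2 to compound 3 (beyond the scatter) lie beyond the scatter, while a number 7 percentage points higher from compound 1 to compound 2 (within the scatter) lies within it. Compound 4 `NC(N)=NC(=O)c1nc(Cl)c(Nc2cccc(Cl)c2)nc1N` differs from compound 3 by chloro in place of hydrogen on an aromatic carbon. For the measured compounds named here, no measured step alters the phenyl ring itself; each swaps the whole group on the ring nitrogen, so none speaks directly to this change, and the measured steps only show the phenyl compound standing highest. The step of a number 6 percentage points higher from compound 3 to compound 4 (within the scatter) is therefore expected to be small, of uncertain direction. Compound 4 is estimated at 50%, between 30% and 70%.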

Compound 4, a percentage reported as inhibition, at one concentration (the size of the read-out at that concentration, not a potency): 47%
For compound 4 the middle estimate is 3 percentage points above the measured one; low and high end bracket the measured number.
By their numbers in this assay, from the lowest: compounds 1 and 2 (each within the scatter of the next); then compounds 3 and 4 (each within the scatter of the next).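

In this assay the step of a number 3 percentage points higher from compound 3 to compound 4 (within the scatter) is the only one that alters the phenyl ring itself, and it shows that chloro on this aromatic carbon leaves the number unchanged within the scatter. The steps of a number 19 percentage points higher from compound 2 to compound 4 (beyond the scatter) and a number 26 percentage points higher from compound 1 to compound 4 (beyond the scatter) lie beyond the scatter, so the 3-chlorophenyl group keeps the lead that phenyl held over cyclohexyl and cyclohexylmethyl. Nothing available here bears on the reason for these numbers.
As far as these compounds go, whether chloro elsewhere on the phenyl ring would behave alike remains open. So does the effect of a methoxy group, an amine or a carboxylic acid on this same carbon.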